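The source may hold more compounds than are shown below. What is called first, only, known or untested is meant among the compounds shown, and "the series" means these compounds.

Measured compounds:
compound 1 `CCCCCCn1cnc2c(Nc3cccc(Cl)c3)nc(N[C@H]3CC[C@H](N)CC3)nc21`, 2300 nM
compound 2 `CCCCn1cnc2c(Nc3cccc(Cl)c3)nc(N[C@H]3CC[C@H](N)CC3)nc21`, 2000 nM
compound 3 `CC(C)=CCn1cnc2c(Nc3cccc(Cl)c3)nc(N[C@H]3CC[C@H](N)CC3)nc21`, 3500 nM

All three share one core and differ only in the chain on the aromatic nitrogen; every value above comes from a functional assay on K562 cells (Homo sapiens) for inhibition, read by fluorescence, with a stated time of 72 h; a lower number here means a stronger inhibitor of growth, a higher number a weaker inhibitor of growth. On the numbers shown compound 3 stands highest, yet its steps to both neighbours, a 1.5-fold higher number from compound 1 to compound 3 (0.18 log units; within the scatter) and a 1.8-fold higher number from compound 2 to compound 3 (0.24 log units; within the scatter), lie within the scatter, as does a 1.2-fold lower number from compound 1 to compound 2 (0.06 log units; within the scatter). Compound 4 `CC(C)=CCC/C(C)=C/Cn1cnc2c(Nc3cccc(Cl)c3)nc(N[C@H]3CC[C@H](N)CC3)nc21` differs from compound 3 in one place: 3-methylbut-2-en-1-yl in place of hydrogen on a saturated chain carbon bound to a double-bonded chain carbon. Only the chain steps bear on this change, and none of them moved the number beyond the scatter, so no step beyond the scatter is expected here either. Compound 4 is therefore expected at 4000 nM, within 1500 nM to 11000 nM. The expected step, a 1.1-fold higher number from compound 3 to compound 4 (0.06 log units; within the scatter), is small.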

Compound 4, concentration for 50% growth inhibition: 2200 nM
Compound 4: middle estimate off by 1.8-fold (0.26 log units), on the high side; the range from low to high includes it.
By their numbers in this assay, from the lowest: compounds 2, 4, 1 and 3 (each within the scatter of the next).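

Adding 3-methylbut-2-en-1-yl on the saturated chain carbon bound to a double-bonded chain carbon brings 5 heavy atoms and a second double bond outside aromatic rings, yet gives a 1.6-fold lower number from compound 3 to compound 4 (0.20 log units; within the scatter). The 3,7-dimethylocta-2,6-dien-1-yl chain also shows no step beyond the scatter against the saturated chains, with a 1.1-fold higher number from compound 2 to compound 4 (0.04 log units; within the scatter) and a 1.0-fold lower number from compound 1 to compound 4 (0.02 log units; within the scatter), so the nitrogen position accepts this longer chain across the compounds shown. No measurement on hand accounts for this flat response. Every chain shown holds carbon only, so whether a chain carrying an amine or a carboxylic acid would move the number beyond the scatter stays open.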